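The source may hold more compounds than are shown below. What is called first, only, known or untested is meant among the compounds shown, and "the series" means these compounds.

Of the compounds shown here, two that share a core have so far been tested in an assay on isolated protein for inhibition of DNA topoisomerase 1 (Homo sapiens), with a stated time of 15 min; a lower number here means a stronger inhibitor, a higher number a weaker inhibitor. Compound 1 `COc1c(N2CC[C@@H](N)C2)c(F)cc2c(=O)c(C(=O)O)cn(Cc3ccc(-c4ccccc4)cc3)c12` gives 92200 nM in this assay. Compound 2 `COc1c(N2CC[C@@H](CN)C2)c(F)cc2c(=O)c(C(=O)O)cn(Cc3ccc(-c4ccc(F)cc4)cc3)c12` gives 60900 nM in this assay, and the two numbers lie within the usual scatter of each other, so neither can be called the stronger inhibitor. Compound 3 `COc1c(N2CC[C@@H](N)C2)c(F)cc2c(=O)c(C(=O)O)cn(Cc3ccc(-c4ccc(F)cc4)cc3)c12` has not yet been measured. It differs from compound 2 in one place: amino in place of aminomethyl on a saturated ring carbon. Among the measured compounds shown here, no measured pair differs only in this way, so the size of this step cannot be read from the numbers at hand; compound 1 carries the amino group as well but lacks the fluorine on the outer ring, so its value reflects two changes at once. The step of a 1.2-fold higher number from compound 2 to compound 3 (0.09 log units; within the scatter) is expected to be small, in no direction beyond the scatter. Compound 3 is therefore estimated at 75000 nM in this assay, with a range from 30000 nM to 190000 nM.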

Compound 3, half-maximal inhibitory concentration: 58600 nM
Estimate against measurement, compound 3: 1.3-fold (0.11 log units) above; low and high end bracket the measured number.
By their numbers in this assay, from the lowest: compounds 3, 2 and 1 (each within the scatter of the next).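

Among the compounds shown here, replacing aminomethyl with amino on the saturated ring carbon gives a 1.0-fold lower number from compound 2 to compound 3 (0.02 log units; within the scatter) in this assay, the first direct reading of this change, and it cannot be told apart from no effect. Fluoro in place of hydrogen on an aromatic carbon gives a 1.6-fold lower number from compound 1 to compound 3 (0.20 log units; within the scatter), also a first direct reading and also not separable from no effect. Nothing available explains why neither change registers in this assay.

Still open, from the compounds shown here alone, is whether a hydroxyl group or a longer aminoethyl chain on the same saturated ring carbon, or a chlorine or methoxy group in place of the fluorine, would move the number beyond the scatter. Each reading also rests on a single pair of compounds, so neither can be assumed to hold with other groups on the shared core.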